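Swapping a chloro-bearing ring for a methoxy-bearing ring

The compounds below may be only part of what the source reports. "The series", "measured", "known", "first", "only" and "open" are said of these compounds alone.

Two compounds with a shared core were measured for their effect on the growth of breast cancer cells. In a functional assay on MCF7 cells (Homo sapiens) for antiproliferative activity, read by sulforhodamine B assay, with a stated time of 72 h, tested at 10 uM (a lower number here means a stronger effect, a higher number a weaker effect of the compound at the concentration tested), compound 1 `COc1cc(Br)cc2c1OC(N)=C(C#N)C2CC(=O)c1ccccc1` gives 99.1%, while compound 2 `COc1cc(Br)cc2c1OC(N)=C(C#N)C2CC(=O)c1ccc(Cl)cc1` gives 49.6%. For the measured compounds named here, the only step between measured compounds is a number 49.5 percentage points lower from compound 1 to compound 2 (beyond the scatter), and it shows that a single change on the ring attached to the carbonyl can shift the read-out strongly. Compound 2 therefore has the lowest number of the two, the stronger effect.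

Compound 3 `COc1cccc(C(=O)CC2C(C#N)=C(N)Oc3c(OC)cc(Br)cc32)c1` is the next compound: 3-methoxyphenyl in place of 4-chlorophenyl on a carbonyl carbon. Going by the values given here, no measured step shows what a methoxy group on this ring does, so the one step from compound 1 to compound 2 can only hint that the ring's substituent matters. Since the chloro that went with the large drop leaves again, the expected step is a number 28.4 percentage points higher from compound 2 to compound 3 (beyond the scatter), back toward the level of compound 1. For compound 3 the estimated value in this assay is 78%, within a wide range of 45% to 100%.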

Compound 3, a percentage reported as activity, at one concentration (the size of the read-out at that concentration, not a potency): 55.9%
Estimate against measurement, compound 3: 22.1 percentage points above; the range from low to high includes it.
By their numbers in this assay, from the lowest: compounds 2 and 3 (each within the scatter of the next); then compound 1.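

In this assay, the large drop seen with the chloro is not tied to that one group: the step for methoxy in place of hydrogen on the ring is a number 43.2 percentage points lower from compound 1 to compound 3 (beyond the scatter). The exchange of 4-chlorophenyl for 3-methoxyphenyl on the carbonyl carbon gives a number 6.3 percentage points higher from compound 2 to compound 3 (within the scatter), so these two substituted rings cannot be told apart in this read-out, and both stand well apart from the unsubstituted ring of compound 1. Nothing available here explains why either group has this effect.

Because the chloro and the methoxy differ in both identity and place on the ring, these compounds cannot separate the effect of the group from that of its location. On these data alone, whether an amine or a carboxylic acid on this ring would give a similar read-out also remains open.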